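From carboxymethoxy to hydroxy, starting at the assay limit

This account rests on a few compounds, and the source may have more. Where it says the series, first, only, none or still open, it means among the compounds named here.

Measured in an ADME assay on Raji cells (Homo sapiens) for cytotoxicity, with a stated time of 72 h; on this read-out higher numbers stand for an effect only at larger amounts of compound and lower numbers for an effect already at smaller amounts:
- compound 1 `O=C(Nc1ccc(F)c(-c2nc3ccccc3o2)c1)c1cc([N+](=O)[O-])ccc1Cl`: > 25000 nM (a limit)
- compound 2 `O=C(O)COc1cc(Cl)c(C(=O)Nc2cccc(-c3nc4ccccc4s3)c2)cc1[N+](=O)[O-]`: > 25000 nM (a limit)

Compound 2 gives no exact number in this assay, only the limit > 25000 nM. Compound 1 also gives only a limit, > 25000 nM. The two results can therefore not be ranked against each other, and what they share is the limit of > 25000 nM in this assay, at which 2 of the 2 values shown sit.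

The next compound is compound 3 `O=C(Nc1cccc(-c2nc3ccccc3s2)c1)c1cc([N+](=O)[O-])c(O)cc1Cl`. It carries hydrogen in place of carboxymethyl on an oxygen on an aromatic ring, which turns carboxymethoxy into hydroxy (hydrogen in place of carboxymethyl on an oxygen on an aromatic ring). Among the measured compounds shown here, no pair of measured compounds shows what a change of this kind does. For the measured compounds named here, the only guide is compound 2 with its limit > 25000 nM, and from it no step beyond the scatter is expected, in either direction. The estimated step is a number no higher from compound 2 to compound 3 (the limit leaves the size open). this assay may well report only a limit once more. If a number does appear, the estimate for compound 3 is 25000 nM, with an expected range from 10000 nM to 50000 nM.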

Compound 3, half-maximal effective concentration: > 25000 nM
Compound 3: no number, only a limit; the forecaster's own chance of this, stated with the estimate: 70%; the middle value sits exactly at the limit.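

Compound 2 and compound 3 both give only a limit in this assay, so the step between them cannot be read: the limit of > 25000 nM in this assay, at which 3 of the 3 values shown sit.

The compounds shown leave open what the change from carboxymethoxy to hydroxy does to this read-out, and at what concentration compound 1, compound 2 or compound 3 would reach a half-maximal effect.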